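This account rests on a few compounds, and the source may have more. Where it says the series, first, only, none or still open, it means among the compounds named here.

In a functional assay on U-373MG ATCC cells (Homo sapiens) for inhibition, read by MTT assay, with a stated time of 72 h (on this read-out higher numbers stand for weaker inhibition and lower numbers for stronger inhibition), three compounds have been measured so far. Compound 1 `CC1(C)CC(NC(=S)Nc2cccc(C#N)c2)c2cc(F)ccc2O1` gives 30000 nM and compound 2 `CC1(C)CC(NC(=S)NCc2ccccc2)c2cc(Cl)ccc2O1` gives 64000 nM on this scale, while compound 3 `CC1(C)CC(NC(=S)Nc2cccc([N+](=O)[O-])c2)c2cc(Cl)ccc2O1` gives 3000 nM as the lowest number of the three. Its gap to each of the other two lies beyond the scatter of repeated measurements, so compound 3 is the strongest inhibitor in this small set.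

The compound still to be measured is compound 4 `CC1(C)CC(NC(=S)Nc2cccc(C#N)c2)c2cc(Cl)ccc2O1` and it differs from compound 3 in a single place: cyano in place of nitro on an aromatic carbon with the rest of the structure unchanged. Among the compounds with values here, no pair of measured compounds shows this swap on its own, so its size can only be judged indirectly. Compound 1, which also carries cyano although its core is not identical, gives 30000 nM and this makes a higher number the more likely outcome. A moderate estimated step of a 2.7-fold higher number from compound 3 to compound 4 (0.43 log units; beyond the scatter) is expected, toward weaker inhibition, though a result within the scatter would not be surprising. For compound 4 the estimated value is 8000 nM with an expected range from 2500 nM to 30000 nM for the measurement.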

Compound 4, half-maximal inhibitory concentration: 7000 nM
The estimate for compound 4 lay 1.1-fold (0.06 log units) above the measured number, and the stated range covers the measured number.
By their numbers in this assay, from the lowest: compound 3; then compound 4; then compound 1; then compound 2.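

Within the data shown here, compound 4 gives the first direct reading of this swap: with the rest of the structure unchanged, cyano in place of nitro on an aromatic carbon, meta to a large group, gives a 2.3-fold higher number from compound 3 to compound 4 (0.37 log units; beyond the scatter) in this assay and so moves toward weaker inhibition, although the step is modest. Compound 4 also links the two other compounds to this series, showing that chloro in place of fluoro on an aromatic carbon gives a 4.3-fold lower number from compound 1 to compound 4 (0.63 log units; beyond the scatter) and that 3-cyanophenyl in place of benzyl on an amide-type nitrogen gives a 9.1-fold lower number from compound 2 to compound 4 (0.96 log units; beyond the scatter) as a further modest step, with both changes moving toward stronger inhibition. No measurement among these results bears on what lies behind any of these shifts.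

Going by these compounds, how a methoxy group or an amine on this same aromatic carbon would compare with nitro and cyano remains open. It is also unknown whether chloro in place of fluoro would produce a step of similar size in a compound carrying nitro rather than cyano, or whether a bromo group at that halogen's place would continue the trend.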